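Amide nitrogen substituent variation on the shared core

This account rests on a few compounds, and the source may have more. Where it says the series, first, only, none or still open, it means among the compounds named here.

The series keeps one core and varies the group on the carbonyl carbon. Compound 1 `CCN(Cc1ccccc1)C(=O)c1nn(-c2ccc(F)cc2)c(OC[C@@H](O)C[C@@H](O)CC(=O)O)c1C(C)C`, compound 2 `COCc1cccc(CNC(=O)c2nn(-c3ccc(F)cc3)c(OC[C@@H](O)C[C@@H](O)CC(=O)O)c2C(C)C)c1` and compound 3 `COc1ccccc1CNC(=O)c1nn(-c2ccc(F)cc2)c(OC[C@@H](O)C[C@@H](O)CC(=O)O)c1C(C)C` have been measured in an assay on microsomes from liver for inhibition of 3-hydroxy-3-methylglutaryl-coenzyme A reductase (Rattus norvegicus); on this read-out higher numbers stand for weaker inhibition and lower numbers for stronger inhibition. Compound 1 gives 14 nM, compound 2 gives 31 nM and compound 3 gives 22 nM. Compound 3 therefore stands second highest of the three numbers, but both its neighbours lie within the scatter: a 1.4-fold lower number from compound 2 to compound 3 (0.15 log units; within the scatter) and a 1.6-fold higher number from compound 1 to compound 3 (0.20 log units; within the scatter). Compound 4 `Cc1cccc(CN(C)C(=O)c2nn(-c3ccc(F)cc3)c(OC[C@@H](O)C[C@@H](O)CC(=O)O)c2C(C)C)c1` differs from compound 3 by methyl(3-methylbenzyl)amino in place of (2-methoxybenzyl)amino on a carbonyl carbon. Among the measured compounds shown here, the steps that bear on this change are a 1.6-fold higher number from compound 1 to compound 3 (0.20 log units; within the scatter) and a 2.2-fold higher number from compound 1 to compound 2 (0.35 log units; beyond the scatter), which together show the two groups with a hydrogen-bond donor giving at most modestly higher numbers than the group without one in compound 1; a 1.4-fold lower number from compound 2 to compound 3 (0.15 log units; within the scatter) shows those two close together. For compound 4 a small step toward lower numbers, or none beyond the scatter, is therefore expected in this assay, about a 1.4-fold lower number from compound 3 to compound 4 (0.14 log units; within the scatter). Compound 4 is estimated at 16 nM, with a range from 7 nM to 36 nM.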

Compound 4, half-maximal inhibitory concentration: 37 nM
Compound 4: middle estimate off by 2.3-fold (0.36 log units), on the low side; measured number outside the range, above it.
By their numbers in this assay, from the lowest: compounds 1, 3, 2 and 4 (each within the scatter of the next, the first and the last beyond it).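

In this assay, taking away the amide hydrogen at this position does not by itself bring the number back to that of compound 1: a 1.7-fold higher number from compound 3 to compound 4 (0.23 log units; within the scatter) and a 1.2-fold higher number from compound 2 to compound 4 (0.08 log units; within the scatter), so compound 4 stays with the two compounds that carry that hydrogen. The two groups without it still read apart, a 2.6-fold higher number from compound 1 to compound 4 (0.42 log units; beyond the scatter), so its absence alone does not set the number on this carbonyl carbon. Nothing measured here accounts for that gap.

Two things change at once between compound 1 and compound 4, the ethyl going to methyl and the 3-methyl appearing on the benzyl, and methyl(benzyl)amino on the carbonyl carbon would separate them. From the compounds shown here alone, how a longer chain, as in benzyl(propyl)amino, would read also remains open.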